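This account rests on a few compounds, and the source may have more. Where it says the series, first, only, none or still open, it means among the compounds named here.

Measured so far in an ADME assay on MT4 cells (Homo sapiens) for cytotoxicity, read by MTT assay, with a stated time of 5 days; on this read-out higher numbers stand for lower toxicity in this test and lower numbers for higher toxicity in this test:
compound 1 `N#CCN1C(=O)N(Cc2cccc(F)c2)S(=O)(=O)n2cccc21`: 172000 nM
compound 2 `O=C1N(Cc2cccc(Cl)c2)c2cccn2S(=O)(=O)N1Cc1cccc(F)c1`: 208000 nM

Compound 2 holds the higher of the two numbers; its nearest neighbour is compound 1, and the step of a 1.2-fold higher number from compound 1 to compound 2 (0.08 log units; within the scatter) lies within the scatter, so the two cannot be ordered. Compound 3 `O=C1N(Cc2ccccc2Br)c2cccn2S(=O)(=O)N1Cc1cccc(F)c1` is not yet measured in this assay. It differs from compound 2 in one place: 2-bromophenyl in place of 3-chlorophenyl on a saturated chain carbon bound to an amide-type nitrogen in a ring. Within the data shown here, only one measured step bears on this position, a 1.2-fold higher number from compound 1 to compound 2 (0.08 log units; within the scatter), and it stayed within the scatter even though it exchanged a nitrile for a whole aromatic ring; the present change keeps a six-membered aromatic ring of carbon only and exchanges one halogen for another. No step beyond the scatter is therefore expected in this assay. The estimate for compound 3 is 200000 nM, with a range of 100000 nM to 400000 nM. The expected step is a 1.0-fold lower number from compound 2 to compound 3 (0.02 log units; within the scatter).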

Compound 3, half-maximal cytotoxic concentration: > 269000 nM
Compound 3: no number, only a limit; the forecaster's own chance of this, stated with the estimate: 30%; at least 1.3-fold (0.12 log units) between middle value and limit.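

In this assay, compound 3 gives no number, only a limit: the limit of > 269000 nM in this assay, at which 1 of the 3 values shown sits.

Read against its neighbours, the record gives an at least 1.2-fold higher number from compound 2 to compound 3 (0.11 log units; that floor lies within the scatter) and an at least 1.5-fold higher number from compound 1 to compound 3 (0.19 log units; that floor lies within the scatter), so both floors stay inside the scatter, and the true size of either step is not fixed. What is new is that 2-bromophenyl, on a saturated chain carbon bound to an amide-type nitrogen in a ring, gives no lower number than 3-chlorophenyl or cyano, so a second halogen-bearing ring joins the series without any sign of higher toxicity in this test.

From the compounds shown here alone, whether compound 3 truly stands apart from compound 2 stays open while its value is only a limit. Also open, going by these compounds, is how an amine, a carboxylic acid or a longer chain at this place would read out in this assay.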